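The source may report more compounds than this note shows. Statements on the series, on what has been measured and on what is new or still open speak of the compounds shown alone.

Compound 1 `O=C(Nc1ccc(Cl)c(-c2nnc3c(Cl)cccn23)c1)c1ccccc1` gives 76900 nM in a functional assay on A549 cells (Homo sapiens) for antiproliferative activity, read by MTT assay, with a stated time of 72 h; on this read-out higher numbers stand for weaker inhibition and lower numbers for stronger inhibition.
Compound 2 `Cc1nc(C(=O)Nc2ccc(Cl)c(-c3nnc4c(Cl)cccn34)c2)cs1` gives > 100000 nM, a limit of this assay rather than a number.
Compound 3 `O=C(Nc1ccc(Cl)c(-c2nnc3c(Cl)cccn23)c1)c1ccccc1Cl` gives > 100000 nM, again a limit rather than a number.

Two of the three values sit at the reporting limit, as the limit of > 100000 nM in this assay, at which 2 of the 3 values shown sit, shows, so compound 3 stands at the weak end of what this assay can report, and the step of an at least 1.3-fold higher number from compound 1 to compound 3 (0.11 log units; that floor lies within the scatter) is only a floor that lies within the scatter. Compound 4 `Cc1cc(Cl)ccc1C(=O)Nc1ccc(Cl)c(-c2nnc3c(Cl)cccn23)c1` differs from compound 3 in one place: 4-chloro-2-methylphenyl in place of 2-chlorophenyl on a carbonyl carbon. Among the measured compounds shown here, no measured step changes the group on the carbonyl carbon in this way. The closest comparisons are an at least 1.3-fold higher number from compound 1 to compound 2 (0.11 log units; that floor lies within the scatter), a floor within the scatter, and a step that the two limits leave unreadable from compound 2 to compound 3. None of them gives a direction for the change to compound 4. Compound 4 is therefore expected to give 100000 nM, between 40000 nM and 300000 nM. The expected step is a number no higher from compound 3 to compound 4 (the limit leaves the size open), most likely reported as a limit again.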

Compound 4, half-maximal inhibitory concentration: > 100000 nM
Compound 4 gave a limit, no number (the forecaster's own chance of this, stated with the estimate: 65%); the middle value sits exactly at the limit.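

In this assay, compound 4 gives > 100000 nM, which is a limit of the assay, so exchanging 2-chlorophenyl for 4-chloro-2-methylphenyl on this carbonyl carbon does not bring back a readable number. Three groups at this place have now ended at the same limit, and only the phenyl of compound 1 gives a number, so the series can hardly rank these groups: the limit of > 100000 nM in this assay, at which 3 of the 4 values shown sit. Against that phenyl, the change is an at least 1.3-fold higher number from compound 1 to compound 4 (0.11 log units; that floor lies within the scatter), and the two steps joining one limit to another cannot be read.

Going by these compounds, it stays open whether any group on this carbonyl carbon gives stronger inhibition than compound 1 does at 76900 nM. A group carrying an amine, or a short chain ending in a carboxylic acid, could test whether this position can give stronger inhibition at all.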